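Series notes: isopropyl in place of phenyl in compound 2

This account rests on a few compounds, and the source may have more. Where it says the series, first, only, none or still open, it means among the compounds named here.

Measured in a functional assay on HTB-54 cells (Homo sapiens) for cytotoxicity, read by MTT assay, with a stated time of 72 h; on this read-out lower numbers stand for stronger inhibition of growth and higher numbers for weaker inhibition of growth:
compound 1 `N#C[Se]c1ccc(NC(=O)OCc2ccc([N+](=O)[O-])cc2)cc1`: 22900 nM
compound 2 `N#C[Se]c1ccc(NC(=O)OCc2ccccc2)cc1`: 27600 nM
compound 3 `O=C(Nc1ccc([Se][Se]c2ccc(NC(=O)OCc3ccc([N+](=O)[O-])cc3)cc2)cc1)OCc1ccc([N+](=O)[O-])cc1`: 31800 nM

Compound 2 stands second highest of the three numbers; its nearest neighbour is compound 3 and its furthest compound 1, and both gaps lie within the scatter. For the measured compounds named here, the one step between measured compounds that differ in one place, a 1.2-fold higher number from compound 1 to compound 2 (0.08 log units; within the scatter), concerns the nitro group and says nothing about the ester side. Compound 4 `CC(C)COC(=O)Nc1ccc([Se]C#N)cc1` differs from compound 2 as follows: isopropyl in place of phenyl on a saturated chain carbon bound to an oxygen next to a carbonyl group. Going by the values given here, no measured step bears on this change, so no step beyond the scatter is expected in this assay. Compound 4 is estimated at 27600 nM, with a range of 11000 nM to 70000 nM, which means an expected step of no change at the digits printed from compound 2 to compound 4 (within the scatter).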

Compound 4, concentration for 50% growth inhibition: 27100 nM
The estimate for compound 4 lay 1.0-fold (0.01 log units) above the measured number; measured number inside the range.
By their numbers in this assay, from the lowest: compounds 1, 4, 2 and 3 (each within the scatter of the next).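

For the compounds shown here, measured in this assay the change at this position, isopropyl in place of phenyl on a saturated chain carbon bound to an oxygen next to a carbonyl group, gives a 1.0-fold lower number from compound 2 to compound 4 (0.01 log units; within the scatter) and is the first step read here. An aromatic ring at this position is therefore not required to keep the number level with compound 2. No evidence on the cause is at hand.

Open, going by these compounds, is whether a longer chain, an amine or a carboxylic acid at this position would also stay within the scatter of compound 2. Also open, on these data alone, is whether the same change would read alike with the nitro group of compound 1 present.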